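Removing One Methoxy Group: Compound 2 to Compound 3

The compounds below may be only part of what the source reports. "The series", "measured", "known", "first", "only" and "open" are said of these compounds alone.

Three closely related compounds share one core and differ only in how many methoxy groups sit on one six-membered aromatic ring of carbon only. Compound 1 `COc1ccc(-c2cc(/C=C/C(=O)c3ccc(N)cc3)[nH]n2)cc1` carries a single methoxy group; compound 2 `COc1cc(-c2cc(/C=C/C(=O)c3ccc(N)cc3)[nH]n2)cc(OC)c1OC` carries three. In a functional assay on A549 cells (Homo sapiens) for cytotoxicity, read by sulforhodamine B assay, with a stated time of 48 h, tested at 1 uM (on this read-out lower numbers stand for a stronger effect and higher numbers for a weaker effect at the one concentration tested), compound 1 gives 84% and compound 2 gives 80%. Within the data shown here, of the two numbers known, compound 2 has the lower one, yet its nearest neighbour, compound 1, sits only a few points higher, within the usual scatter, so nothing can be said about which of the two acts more strongly.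

Compound 3 `COc1ccc(-c2cc(/C=C/C(=O)c3ccc(N)cc3)[nH]n2)cc1OC` has not yet been measured in this assay. It differs from compound 2 in one place: hydrogen in place of methoxy on an aromatic carbon. Among the measured compounds shown here, no step between measured compounds of this kind exists, so the change can only be judged from the two values in hand, which both lie in the same high region. The expectation is therefore a step from compound 2 to compound 3 of a number 2 percentage points higher from compound 2 to compound 3 (within the scatter), nothing beyond the scatter. Compound 3 is estimated at 82%, with a range from 70% to 94%.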

Compound 3, a percentage reported as activity, at one concentration (the size of the read-out at that concentration, not a potency): 89%
For compound 3 the middle estimate is 7 percentage points below the measured one; measured number inside the range.
By their numbers in this assay, from the lowest: compounds 2, 1 and 3 (each within the scatter of the next).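

Removing the methoxy group on an aromatic carbon, ortho to a methoxy group and meta to a large group, gives in this assay a number 9 percentage points higher from compound 2 to compound 3 (within the scatter), while the opposite kind of change, methoxy in place of hydrogen on an aromatic carbon, gives a number 5 percentage points higher from compound 1 to compound 3 (within the scatter). Among these compounds, these are the first direct one-place comparisons, and both show that a single change between hydrogen and methoxy does not shift the read-out beyond the usual scatter. At the one concentration tested, the compounds with one, two and three methoxy groups therefore cannot be told apart, and no trend with the number of methoxy groups can be claimed.

The compounds shown leave open whether a different group at this place, such as an amine, a carboxylic acid or a longer chain like ethoxy, would produce a step beyond the scatter. No measurement at hand speaks to why these methoxy changes leave the read-out within the scatter.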